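The source may hold more compounds than are shown below. What is called first, only, known or untested is meant among the compounds shown, and "the series" means these compounds.

Going by the values given here, the two compounds measured so far share one core and differ only in the group on the outer benzene ring. Compound 1 `COC(=O)c1cccc(-c2cnc(Nc3ccc(F)cc3)o2)c1` carries a methyl ester there; in an ADME assay on microsomes from liver (Homo sapiens) for metabolic stability, read by LC-MS, using NADPH (a lower number here means that the compound disappears faster, a higher number that the compound lasts longer), compound 1 gives only a limit, < 0.0167 h, so no number is known for it. Among the compounds with values here, compound 2 `CNC(=O)c1cccc(-c2cnc(Nc3ccc(F)cc3)o2)c1` carries a methylcarbamoyl group instead; in this assay compound 2 gives 0.423 h, which is the only actual number in this small set. The step of an at least 25-fold higher number from compound 1 to compound 2 (1.40 log units; beyond the scatter) is therefore large, though its true size rests on the limit of < 0.0167 h in this assay, at which 1 of the 2 values shown sits, and is known only as a floor.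

Compound 3 `Cc1noc(-c2cccc(-c3cnc(Nc4ccc(F)cc4)o3)c2)n1` takes the change one stage further: 3-methyl-1,2,4-oxadiazol-5-yl in place of methylcarbamoyl on an aromatic carbon. Within the data shown here, the only measured step concerned the exchange of methoxy for methylamino on the carbonyl carbon, and the carbonyl itself now leaves together with the methylcarbamoyl group, so that step bears only loosely on the present one. Among the measured compounds shown here, no measured step speaks against the new ring, and none for it. The expected step of a 1.4-fold lower number from compound 2 to compound 3 (0.15 log units; within the scatter) is therefore held small, within the scatter or at most a modest loss. For compound 3 the estimate in this assay is 0.3 h, with a range from 0.08 h to 1.2 h.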

Compound 3, half-life: 0.575 h
The estimate for compound 3 lay 1.9-fold (0.28 log units) below the measured number; measured number inside the range.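

In this assay, the exchange of the methylcarbamoyl group for 3-methyl-1,2,4-oxadiazol-5-yl on this aromatic carbon gives a 1.4-fold higher number from compound 2 to compound 3 (0.13 log units; within the scatter), so a ring with no hydrogen-bond donor and no carbonyl serves here as well as the amide does, and the amide hydrogen is not needed to reach this number. Set against the methoxycarbonyl group, the same ring gives an at least 34-fold higher number from compound 1 to compound 3 (1.53 log units; beyond the scatter), so two different groups, one that keeps the carbonyl and one that does not, each stand a large step away from compound 1. The true size of that step is not known, as it rests on a limit for compound 1: the limit of < 0.0167 h in this assay, at which 1 of the 3 values shown sits.

The compounds shown leave open how a nitrile or a carboxylic acid in this place would fare in this assay, and whether a longer chain on the amide nitrogen would move the number. They also leave open whether a change elsewhere on the shared core, such as chlorine in place of the fluorine, would take the number beyond what compound 2 and compound 3 show.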